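From bromo to 4-methoxyphenyl on a silent core

The source may report more compounds than this note shows. Statements on the series, on what has been measured and on what is new or still open speak of the compounds shown alone.

compound 1 `FC(F)(F)c1nc2c(Br)cccc2c(Cl)c1Br`: > 300000 nM, a limit of the assay
compound 2 `FC(F)(F)c1nc2c(-c3ccccc3)cccc2c(-c2ccccc2)c1-c1ccccc1`: > 300000 nM, a limit of the assay
compound 3 `Cc1ccc(-c2c(C(F)(F)F)nc3c(-c4ccc(C)cc4)cccc3c2-c2ccc(C)cc2)cc1`: > 300000 nM, a limit of the assay

The three measured compounds were read in an assay for inhibition of ectonucleoside triphosphate diphosphohydrolase 3 (Homo sapiens), read by malachite green, with a stated time of 10 min; on this read-out lower numbers stand for stronger inhibition and higher numbers for weaker inhibition. Compound 1 gives only the limit > 300000 nM, which is an edge of the assay and not a number. Compound 2 likewise gives only the limit > 300000 nM. Compound 3 also gives only the limit > 300000 nM. Compound 1 therefore stands nowhere apart from the others, since all values shown sit at the limit of > 300000 nM in this assay, at which 3 of the 3 values shown sit.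

The unmeasured compound 4 `COc1ccc(-c2cccc3c(Cl)c(Br)c(C(F)(F)F)nc23)cc1` differs from compound 1 by 4-methoxyphenyl in place of bromo on an aromatic carbon. For the measured compounds named here, no step between measured compounds exists, so no direction can be read from the data. Given that every shown value rests at the limit of > 300000 nM in this assay, at which 3 of the 3 values shown sit, the step of a number no higher from compound 1 to compound 4 (the limit leaves the size open) is expected to be none beyond the scatter. Compound 4 is estimated at 300000 nM, within 50000 nM to 1500000 nM.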

Compound 4, half-maximal inhibitory concentration: > 300000 nM
Compound 4 ended at the assay's limit; the forecaster's own chance of this, stated with the estimate: 75%; the middle value sits exactly at the limit.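

No step can be read from compound 1 to compound 4, since both give only a limit of the assay: the limit of > 300000 nM in this assay, at which 4 of the 4 values shown sit.

The compounds shown leave open which change to the shared core, if any, would give a readable number in this assay.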